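Swapping a chlorophenyl for a pyridyl on a styryl chromone

The source may report more compounds than this note shows. Statements on the series, on what has been measured and on what is new or still open speak of the compounds shown alone.

Measured compounds:
compound 1, `COc1cc(OC)c2c(=O)cc(/C=C/c3ccc(Cl)cc3)oc2c1`: 26900 nM
compound 2, `COc1cc(/C=C/c2cc(=O)c3c(OC)cc(OC)cc3o2)cc(OC)c1`: 23700 nM

In a functional assay on SKHep cells (Homo sapiens) for antiproliferative activity, read by MTT assay, with a stated time of 12 h (on this read-out lower numbers stand for stronger inhibition and higher numbers for weaker inhibition), compound 1 gives 26900 nM, the highest of the two numbers, while compound 2 gives 23700 nM, a difference that sits within the usual scatter, so the two cannot be told apart. Compound 3, `COc1cc(OC)c2c(=O)cc(/C=C/c3ccncc3)oc2c1`, has not been measured. It differs from compound 1 by pyridin-4-yl in place of 4-chlorophenyl on a double-bonded chain carbon bound to a double-bonded chain carbon. Among the compounds with values here, no measured pair shows what such a change does here, so the step from compound 1 to compound 3 in this assay is expected to be small, a 1.1-fold higher number from compound 1 to compound 3 (0.05 log units; within the scatter), with weaker inhibition as likely as stronger. Compound 3 is therefore estimated at 30000 nM, within a range of 10000 nM to 90000 nM.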

Compound 3, half-maximal inhibitory concentration: > 40000 nM
Compound 3: a limit, no number (the forecaster's own chance of this, stated with the estimate: 25%); middle value at least 1.3-fold (0.12 log units) away from the limit.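

In this assay, compound 3 yields a limit and not a number: the limit of > 40000 nM in this assay, at which 1 of the 3 values shown sits. Pyridin-4-yl in place of 4-chlorophenyl at this place gives an at least 1.4-fold higher number from compound 1 to compound 3 (0.17 log units; that floor lies within the scatter), the first reading of any change here. As far as these compounds go, it points towards weaker inhibition, but the true size of the step is unknown, and its floor alone cannot separate the two compounds.

From the compounds shown here alone, how far compound 3 lies past its limit remains open. So does what an amine or a carboxylic acid on the phenyl ring at this place would do to the number.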